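A thiophene swap from compound 1 to compound 4

This account rests on a few compounds, and the source may have more. Where it says the series, first, only, none or still open, it means among the compounds named here.

- Compound 1 `Cc1cc(-c2nc3sc(C)cn3c2/C=N/NC(=N)N)c(C)s1`: 25100 nM
- Compound 2 `Cc1cn2c(/C=N/Nc3ccccn3)c(-c3ccc(Cl)c([N+](=O)[O-])c3)nc2s1`: 30900 nM
- Compound 3 `Cc1cc(-c2nc3sccn3c2/C=N/NC(=N)N)c(C)s1`: 33100 nM

All three were tested in a functional assay on cells (Cancer cell lines, Homo sapiens) for inhibition (on this read-out higher numbers stand for weaker inhibition of growth and lower numbers for stronger inhibition of growth), and compound 1 stands level with the other two, within the usual scatter. Compound 4 `Cc1cn2c(/C=N/NC(=N)N)c(-c3cccs3)nc2s1` keeps the core of compound 1 and changes one group: thiophen-2-yl in place of 2,5-dimethylthiophen-3-yl on an aromatic carbon. Going by the values given here, no measured step covers this exact swap. The closest guide is a 1.3-fold higher number from compound 1 to compound 3 (0.12 log units; within the scatter), where hydrogen takes the place of methyl on an aromatic carbon. Among the compounds with values here, compound 2 differs from compound 1 in several places, and the numbers so far stay close together, with compound 2 at 30900 nM. The expected step in this assay, a 1.1-fold higher number from compound 1 to compound 4 (0.05 log units; within the scatter), therefore stays within the scatter. For compound 4 the estimate is 28000 nM, with an expected range from 14000 nM to 60000 nM.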

Compound 4, concentration for total growth inhibition: 25100 nM
Estimate against measurement, compound 4: 1.1-fold (0.05 log units) above, and the stated range covers the measured number.
By their numbers in this assay, from the lowest: compounds 1, 4, 2 and 3 (each within the scatter of the next).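

In this assay, swapping 2,5-dimethylthiophen-3-yl for thiophen-2-yl on this aromatic carbon gives no change at the digits printed from compound 1 to compound 4 (within the scatter). Going by these compounds alone, the earlier step touched only a methyl on the shared core, so this is the first direct look at the thiophene group itself: removing its methyl groups and changing its point of attachment leaves the number in place. Nothing measured here explains this outcome.

Going by these compounds, whether an amine or a carboxylic acid at this position would shift the number beyond the scatter remains open.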